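From 2-hydroxyethyl to 2-acetoxyethyl on a shared core

A few compounds are considered here, and "the series" means these few. Any claim that something is new, unique, unknown or untested is made for them only; others in the source may bear on it.

Compound 1 `COCCc1sc(S(=O)(=O)NC(=O)Nc2cc(OC)cc(N)n2)cc1C` gives 97000 nM
Compound 2 `Cc1cc(S(=O)(=O)NC(=O)Nc2cc(C(F)(F)F)c(F)c(N)n2)sc1CCO` gives 4000 nM

In a functional assay on cells (Hepatocyte, Mus musculus), with a stated time of 6 h (on this read-out lower numbers stand for an effect already at smaller amounts and higher numbers for an effect only at larger amounts of compound), compound 2 stands at 4000 nM as the lower of the two numbers, and compound 1 at 97000 nM lies beyond the scatter from it. The two compounds differ in more than one place, so their gap cannot be tied to any single group.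

Compound 3 `CC(=O)OCCc1sc(S(=O)(=O)NC(=O)Nc2cc(C(F)(F)F)c(F)c(N)n2)cc1C` has not yet been measured. It keeps the core of compound 2 and carries acetyl in place of hydrogen on an oxygen on a saturated carbon, so that 2-hydroxyethyl becomes 2-acetoxyethyl. Going by the values given here, no measured pair shows what this change does, which leaves compound 2 at 4000 nM as the only anchor for the expectation. In this assay no step beyond the scatter is expected, with a slight lean towards lower numbers. The expected size is a 1.6-fold lower number from compound 2 to compound 3 (0.20 log units; within the scatter) and that estimate remains uncertain in both directions. For compound 3 the estimate is 2500 nM with an expected range from 600 nM to 10000 nM on this read-out.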

Compound 3, half-maximal effective concentration: 2700 nM
The estimate for compound 3 lay 1.1-fold (0.03 log units) below the measured number; the range from low to high includes it.
By their numbers in this assay, from the lowest: compounds 3 and 2 (each within the scatter of the next); then compound 1.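

In this assay the change from 2-hydroxyethyl to 2-acetoxyethyl on the shared core amounts to a 1.5-fold lower number from compound 2 to compound 3 (0.17 log units; within the scatter) and therefore does not separate the two compounds on this read-out. Going by these compounds alone, this is the first step at this position that can be read in one place: the earlier pair differed in more than one place and could not show it. Here the hydrogen on the oxygen gives way to acetyl, with its three heavy atoms and added carbonyl, and no step beyond the scatter results; nothing available bears on why this is so.

Still open, going by these compounds, is whether a larger acyl group on the same oxygen, such as benzoyl, or a replacement of the hydroxy by an amine or a carboxylic acid would also stay within the scatter of compound 2 in this assay or would move the number beyond it. Equally open, on these data alone, is what a longer chain carrying the acetoxy group would do, as this single step says nothing about the length of the chain.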